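The source may report more compounds than this note shows. Statements on the series, on what has been measured and on what is new or still open speak of the compounds shown alone.

Measured in a functional assay on MDA-MB-231 cells (Homo sapiens) for inhibition, read by sulforhodamine B assay, tested at 10 uM; a lower number here means less inhibition, a higher number more inhibition at the concentration tested (going by the name of the read-out):
compound 1 `CC(=O)N1N=C(c2ccc(N3CCN(C)CC3)cc2)CC1c1ccc(N(C)C)cc1` gives -1%;
compound 2 `CN1CCN(c2ccc(C3=NN(C(=O)CCCl)C(c4ccc(N(C)C)cc4)C3)cc2)CC1` gives 2.4%;
compound 3 `CC(=O)N1N=C(c2ccc(-n3ccnc3)cc2)CC1c1ccc(N(C)C)cc1` gives 5%.

Compound 2 differs from compound 1 by chloromethyl in place of hydrogen on a saturated chain carbon bound to a carbonyl carbon, and that step is a number 3.4 percentage points higher from compound 1 to compound 2 (within the scatter). Compound 3 differs from compound 1 in its core by 1H-imidazol-1-yl in place of 4-methylpiperazin-1-yl on an aromatic carbon, a step of a number 6 percentage points higher from compound 1 to compound 3 (within the scatter). All three measured numbers lie within the scatter of one another, so the inhibition in this assay is level among these compounds. Compound 4 `CN(C)c1ccc(C2CC(c3ccc(-n4ccnc4)cc3)=NN2C(=O)CCCl)cc1` is not yet measured; it carries the same change relative to compound 3, (chloromethyl in place of hydrogen on a saturated chain carbon bound to a carbonyl carbon), at the same place, so this change occurs twice among these compounds. In this assay a step of a number 3 percentage points higher from compound 3 to compound 4 (within the scatter) is expected, because the same change gave a number 3.4 percentage points higher from compound 1 to compound 2 (within the scatter). For compound 4 the estimated value is 8%, expected between -5% and 22%.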

Compound 4, a percentage reported as inhibition, at one concentration (the size of the read-out at that concentration, not a potency): 2.1%
Compound 4: the middle estimate sits 5.9 percentage points above what was measured; measured number inside the range.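

In this assay, the chloromethyl change reads the same on both cores: the same change on two cores in this assay, a number 3.4 percentage points higher (within the scatter) from compound 1 to compound 2 and a number 2.9 percentage points lower (within the scatter) from compound 3 to compound 4, 6.3 percentage points apart, within the scatter of two such steps

The change to 1H-imidazol-1-yl from 4-methylpiperazin-1-yl also reads the same on both cores: the same change on two cores in this assay, a number 6 percentage points higher (within the scatter) from compound 1 to compound 3 and a number 0.3 percentage points lower (within the scatter) from compound 2 to compound 4, 6.3 percentage points apart, within the scatter of two such steps

The new steps, a number 2.9 percentage points lower from compound 3 to compound 4 (within the scatter) and a number 0.3 percentage points lower from compound 2 to compound 4 (within the scatter), show no sign that either change depends on the core, but they do not show that a change with a clear effect would carry from one core to another, as none of these steps leaves the scatter.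

The compounds shown leave open whether an amine, a carboxylic acid or a longer chain in place of the 2-chloroethyl group would move the number in this assay.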